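A few compounds are considered here, and "the series" means these few. Any claim that something is new, unique, unknown or untested is made for them only; others in the source may bear on it.

Working notes on the series: compound 1 `O=C(CN(C(=O)C1CCCCC1)C1CCCCC1)Nc1cc(F)cc(F)c1` stands as "not determined" (no result reported) in a physicochemical assay for lipophilicity (a higher number here means a more lipophilic compound, a lower number a more polar compound), and so gives no number. In this assay compound 2 `COc1ccc(C(=O)N(Cc2cc(-c3ccccc3)on2)C2CCCCC2)cc1` gives 4.2 and compound 3 `O=C(CN(C(=O)c1ccc(-c2ccccn2)cc1)C1CCCOC1)Nc1cc(F)cc(F)c1` gives 2.7 as the lower of the two numbers, a gap beyond the scatter. The change from compound 3 to compound 4 `O=C(CN(C(=O)c1ccc(-c2ccccn2)cc1)C1CCOC1)Nc1cc(F)cc(F)c1` is oxolan-3-yl in place of oxan-3-yl on an amide-type nitrogen, with oxolan-3-yl in place of oxan-3-yl on an amide-type nitrogen as the counted difference. Among the compounds with values here, no pair of measured compounds differs in one place, so nothing gauges this change directly. A small downward step in this assay is expected, close to the usual scatter, and a number 0.30 log units lower from compound 3 to compound 4 (within the scatter) is the estimated size. Compound 4 is expected at 2.4 with an estimated range of 2 to 2.8 for its measurement.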

Compound 4, distribution coefficient: 2.5
Beside the measured number, compound 4's estimate is 0.10 log units below it; the measured number falls inside the stated range.
By their numbers in this assay, from the lowest: compounds 4 and 3 (each within the scatter of the next); then compound 2.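

Within the data shown here, this is the first direct reading of the change on an amide-type nitrogen: in this assay, oxolan-3-yl in place of oxan-3-yl gives a number 0.20 log units lower from compound 3 to compound 4 (within the scatter), so the two rings cannot be told apart at this position. No available evidence accounts for this reading. Still open, going by these compounds, is how an amine such as piperidin-4-yl, or an open chain such as 2-methoxyethyl, would read on the same nitrogen. Also open, on these data alone, is whether the step from oxan-3-yl to oxolan-3-yl holds on a core other than that of compound 3.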